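The compounds below may be only part of what the source reports. "The series", "measured", "known", "first", "only" and "open" are said of these compounds alone.

Compound 1 `O=C(/C=C/c1ccccc1Cl)c1ccc(OCc2ccccc2)cc1`: 99.7%
Compound 2 `O=C(/C=C/c1ccc(Cl)cc1)c1ccccc1`: 100%

Two compounds share a measurement here. In a functional assay on HCT-116 cells (Homo sapiens) for antiproliferative activity, read by sulforhodamine B assay, with a stated time of 3 days, tested at 50 uM (a lower number here means a weaker effect, a higher number a stronger effect of the compound at the concentration tested), compound 2 gives 100%, the highest of the two numbers recorded. In this assay compound 1 gives 99.7%, a value that lies within the usual scatter of compound 2, so the two cannot be told apart on these numbers, and both sit close to complete inhibition.

Compound 3 `O=C(/C=C/c1ccc(F)cc1)c1ccccc1` has not yet been measured in this assay. It differs from compound 2 in one place: fluoro in place of chloro on an aromatic carbon. Among the measured compounds shown here, no step between two measured compounds is available to show how such a swap plays out in this assay, so the expectation rests on the one anchor, compound 2 at 100%. Since that anchor already sits at the top of the scale, the step is expected to be small, either none beyond the scatter or a modest drop. For compound 3 the estimated value in this assay is 93%, with a range from 75% to 100%, which corresponds to an expected step of a number 7 percentage points lower from compound 2 to compound 3 (within the scatter).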

Compound 3, a percentage reported as inhibition, at one concentration (the size of the read-out at that concentration, not a potency): 100%
For compound 3 the middle estimate is 7 percentage points below the measured one; measured number inside the range.
By their numbers in this assay, from the lowest: compounds 1, 2 and 3 (each within the scatter of the next).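

In this assay, placing fluoro instead of chloro on this aromatic carbon, para to a large group, brings no change at the digits printed from compound 2 to compound 3 (within the scatter) and shows that, at the single concentration tested, the read-out does not separate these two groups at this position. Among the compounds shown here, both compounds sit at the top of the scale, however, so a real difference in potency could stay hidden, and this result shows only that neither group falls short of near-complete inhibition at that concentration. No supporting data bear on why the swap leaves the read-out unchanged.

As far as these compounds go, whether an amine or a carboxylic acid at this position would keep inhibition this high remains open. Also open, from the compounds shown here alone, is whether compound 2 and compound 3 would separate at lower concentrations, where the read-out would no longer sit at the top of the scale.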